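Notes on the ring-nitrogen substituent series

The source may report more compounds than this note shows. Statements on the series, on what has been measured and on what is new or still open speak of the compounds shown alone.

The shared core carries a variable group on an amide-type nitrogen in a ring. Compound 1 `O=C1NC2(CC2c2ccc3cccc(OCc4ccccc4)c3n2)C(=O)N1c1ccccc1` bears phenyl there, compound 2 `O=C1NC2(CC2c2ccc3cccc(OCc4ccccc4)c3n2)C(=O)N1C1CCCCC1` cyclohexyl and compound 3 `O=C1NC2(CC2c2ccc3cccc(OCc4ccccc4)c3n2)C(=O)N1Cc1ccccc1` benzyl. In a functional assay on the whole organism (strain Kunming) with Mus musculus as the target, in the maximal electroshock model, with a stated time of 4 h (on this read-out higher numbers stand for an effect only at larger amounts of compound and lower numbers for an effect already at smaller amounts), compound 1 gives 300 mg/kg, compound 2 gives 300 mg/kg and compound 3 gives 300 mg/kg. The three steps among them, no change at the digits printed from compound 1 to compound 2 (within the scatter), no change at the digits printed from compound 1 to compound 3 (within the scatter) and no change at the digits printed from compound 2 to compound 3 (within the scatter), all leave the read-out where it was, so compound 3 stands level with compounds 1 and 2 and the numbers do not separate it from either.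

Among the measured compounds shown here, compound 4 `O=C1NC2(CC2c2ccc3cccc(OCc4ccccc4)c3n2)C(=O)N1c1ccc([N+](=O)[O-])cc1` differs from compound 3 as follows: 4-nitrophenyl in place of benzyl on an amide-type nitrogen in a ring Of the measured steps, no change at the digits printed from compound 1 to compound 3 (within the scatter) is the one that exchanges phenyl for benzyl on the same nitrogen, and it was flat; no change at the digits printed from compound 1 to compound 2 (within the scatter) and no change at the digits printed from compound 2 to compound 3 (within the scatter) were flat too. For the measured compounds named here, no measured step brings in a nitro group, so that part of the change is untested. The expectation is therefore a step of no change at the digits printed from compound 3 to compound 4 (within the scatter) in this assay, none beyond the scatter. Compound 4 is estimated at 300 mg/kg, with a range of 150 mg/kg to 600 mg/kg.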

Compound 4, minimum effective dose: 300 mg/kg
Compound 4: the middle estimate sits on the measured number at the digits printed, and the stated range covers the measured number.
By their numbers in this assay, from the lowest: compounds 1, 2, 3 and 4 (each within the scatter of the next).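

In this assay, nitro in place of hydrogen on an aromatic carbon, the first substituent tried on the phenyl group, gives no change at the digits printed from compound 1 to compound 4 (within the scatter) and leaves the read-out where it was. 4-Nitrophenyl also sits level with the two non-phenyl groups, with no change at the digits printed from compound 3 to compound 4 (within the scatter) against benzyl and no change at the digits printed from compound 2 to compound 4 (within the scatter) against cyclohexyl, so the flat picture on this nitrogen now extends to a group carrying hydrogen-bond acceptors where benzyl has none. Nothing available explains this flat response.

Going by these compounds, since all four compounds share one value, it remains open whether any group on this nitrogen can shift the read-out, for instance an amine or a carboxylic acid in place of nitro, a longer alkyl chain, or a plain hydrogen. The rest of the shared core stays constant, so the response to changes elsewhere is also unknown.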